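Changing one amide group at the cytotoxicity limit

The source may report more compounds than this note shows. Statements on the series, on what has been measured and on what is new or still open speak of the compounds shown alone.

Of the compounds shown here, two have been tested so far in an ADME assay on HEK293 cells (Homo sapiens) for cytotoxicity, read by resazurin assay, with a stated time of 72 h (on this read-out lower numbers stand for higher toxicity in this test and higher numbers for lower toxicity in this test), and their results are these.
- Compound 1 `CCc1cccc(CNC(=O)c2nc3c(F)ccc(COCc4ccc(C(=O)O)cc4)c3c(=O)[nH]2)c1` gives > 20000 nM (a limit)
- Compound 2 `COc1cccc(CNC(=O)c2nc3cccc(COCc4ccc(C(=O)O)cc4)c3c(=O)[nH]2)c1` gives > 20000 nM (a limit)

Compound 2 gives > 20000 nM as its result, and this is a limit of the assay and not a number. Compound 1 gives > 20000 nM and this too is a limit. Among the compounds with values here, the evidence so far is the limit of > 20000 nM in this assay, at which 2 of the 2 values shown sit, and no measured step between compounds exists to lean on.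

The next compound, compound 3 `CCc1cccc(C(C)NC(=O)c2nc3cccc(COCc4ccc(C(=O)O)cc4)c3c(=O)[nH]2)c1`, keeps the rest of the structure of compound 2 and changes one group on an amide-type nitrogen, with 1-(3-ethylphenyl)ethyl in place of 3-methoxybenzyl (1-(3-ethylphenyl)ethyl in place of 3-methoxybenzyl on an amide-type nitrogen).

Resting on the limit of compound 2 at > 20000 nM as the only anchor for this change, the expectation in this assay is no step beyond the usual scatter and no clear direction. The expected change, which is only an estimate, is a number no higher from compound 2 to compound 3 (the limit leaves the size open) and it should be read with that caution. Compound 3 is estimated at 20000 nM with an expected range from 10000 nM to 40000 nM and the assay may well report only a limit once more.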

Compound 3, half-maximal cytotoxic concentration: > 20000 nM
Compound 3: a limit, no number; the forecaster's own chance of this, stated with the estimate: 80%; the middle value lies on the limit itself.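

In this assay compound 3 gives > 20000 nM, which is a limit of the assay and not a number. Compound 2 also stands at a limit, and the step from compound 2 to compound 3 cannot be read. The compounds shown leave open at what concentration, if any, each would become toxic to these cells, and whether 1-(3-ethylphenyl)ethyl in place of 3-methoxybenzyl changes that concentration.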